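Adding pyridin-2-yl to the free ring nitrogen

The source may report more compounds than this note shows. Statements on the series, on what has been measured and on what is new or still open speak of the compounds shown alone.

Compound 1 (`CN(C[C@H]1Cc2c(cccc2N2CCN(Cc3ccccn3)CC2)CN1)[C@H]1CCCc2cccnc21`) 4.2%
Compound 2 (`CN(C[C@H]1Cc2c(cccc2N2CCNCC2)CN1)[C@H]1CCCc2cccnc21`) 99.7%

Going by the values given here, in an ADME assay on microsomes from liver (Homo sapiens) for metabolic stability, read by LC-MS, with a stated time of 10 min (a higher number here means that more of the compound is left, a lower number that less of the compound is left), compound 2 gives 99.7% and holds the higher of the two numbers so far. The change to compound 3 (`CN(C[C@H]1Cc2c(cccc2N2CCN(c3ccccn3)CC2)CN1)[C@H]1CCCc2cccnc21`) is pyridin-2-yl in place of hydrogen on an amine nitrogen in a ring and it puts pyridin-2-yl in place of hydrogen on an amine nitrogen in a ring. Among the compounds with values here, one measured step bears on this, a number 95.5 percentage points higher from compound 1 to compound 2 (beyond the scatter) and it is large, beyond the scatter, with hydrogen replacing (pyridin-2-yl)methyl on an amine nitrogen in a ring. Within the data shown here, the group in compound 3 is not the one in compound 1, so that step is only a guide, and no measured compound carries pyridin-2-yl itself. A large fall is expected, an estimated a number 69.7 percentage points lower from compound 2 to compound 3 (beyond the scatter) in this assay and somewhat smaller than the step just described. For compound 3 the expected value is 30% with an estimated range from 8% to 65% in repeated measurements.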

Compound 3, percent of the compound remaining: 27.4%
For compound 3 the middle estimate is 2.6 percentage points above the measured one; the range from low to high includes it.
By their numbers in this assay, from the lowest: compound 1; then compound 3; then compound 2.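

In this assay pyridin-2-yl placed directly on the amine nitrogen in the ring gives a number 72.3 percentage points lower from compound 2 to compound 3 (beyond the scatter) and so shows that the loss at this position is not confined to (pyridin-2-yl)methyl. Against that group, the directly attached ring gives a number 23.2 percentage points higher from compound 1 to compound 3 (beyond the scatter) and so shows that the outcome depends on how the group is attached, not only on whether a substituent is present. No evidence at hand explains either step.

The compounds shown leave open whether any substituent on this nitrogen brings such a fall or whether it is tied to the ring nitrogen of pyridin-2-yl. Phenyl, a small methyl group or an acetyl group at the same place would bear on that question, as would a longer chain carrying pyridin-2-yl.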